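Trading the Dichlorophenyl Amide for a Plain Alkyl Chain

The source may report more compounds than this note shows. Statements on the series, on what has been measured and on what is new or still open speak of the compounds shown alone.

Compound 1 `Cn1c(Cc2nn(C)c(=O)c3ccccc23)nnc1SCCCC(=O)Nc1ccc(Cl)cc1Cl` and compound 2 `Cn1c(Cc2nn(C)c(=O)c3ccccc23)nnc1SCCCCCC(=O)Nc1ccc(Cl)cc1Cl` share one core and differ only in the length of the chain between the sulfur and the amide. In an assay on isolated protein (Mus musculus) for inhibition of IL15-IL15 receptor (Homo sapiens), read by resazurin assay, with stated times of 30 min and 2.5 days (a higher number here means a weaker inhibitor, a lower number a stronger inhibitor), compound 1 gives 9800 nM and compound 2 gives 4100 nM; compound 2 therefore holds the lower of the two numbers, and its gap to compound 1 lies beyond the scatter. Compound 3 `CCCCCCCCCCSc1nnc(Cc2nn(C)c(=O)c3ccccc23)n1C` arises from compound 2 by pentyl in place of (2,4-dichlorophenyl)carbamoyl on a saturated chain carbon, five bonds along the chain from a sulfur. Within the data shown here, no measured pair shows a change of this kind, so the step is expected to be upward and beyond the scatter, as a 3.7-fold higher number from compound 2 to compound 3 (0.56 log units; beyond the scatter). Compound 3 is expected to give 15000 nM, within 4000 nM to 60000 nM.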

Compound 3, half-maximal inhibitory concentration: 7600 nM
For compound 3 the middle estimate is 2.0-fold (0.30 log units) above the measured one; the range from low to high includes it.
By their numbers in this assay, from the lowest: compounds 2, 3 and 1 (each within the scatter of the next, the first and the last beyond it).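

In this assay there is a 1.9-fold higher number from compound 2 to compound 3 (0.27 log units; within the scatter) with pentyl in place of (2,4-dichlorophenyl)carbamoyl, and there is a 1.3-fold lower number from compound 1 to compound 3 (0.11 log units; within the scatter) with heptyl in its place. The earlier pair varied only the chain length, whereas these steps show that the whole carbamoyl group, with its aromatic ring and chlorines, can be exchanged for a plain alkyl chain without a step beyond the scatter. Nothing available explains this result.

Going by these compounds, whether a carboxylic acid, an amine or a longer alkyl chain at this chain end would give a different number remains open.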